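Swapping the hydroxylated aryl for a trimethoxyphenyl

The source may hold more compounds than are shown below. What is called first, only, known or untested is meant among the compounds shown, and "the series" means these compounds.

Three close relatives of one acylhydrazone urea have been tested in a functional assay on U-87MG ATCC cells (Homo sapiens) for cytotoxicity, read by MTT assay, with a stated time of 72 h; a lower number here means a stronger inhibitor, a higher number a weaker inhibitor. Compound 1 `CN(C)CCn1cnnc1-c1cc(Oc2ccc(NC(=O)N/N=C/c3ccc(O)cc3)cc2F)ccn1` gives 7750 nM. Within the data shown here, compound 2 `CN(C)CCn1cnnc1-c1cc(Oc2ccc(NC(=O)N/N=C/c3c(O)ccc4ccccc34)cc2F)ccn1` gives 620 nM, and the step of a 13-fold lower number from compound 1 to compound 2 (1.10 log units; beyond the scatter) is the only large change in this small set. Compound 3 `Cc1cc(/C=N/NC(=O)Nc2ccc(Oc3ccnc(-c4nncn4CCN(C)C)c3)c(F)c2)cc(C)c1O` gives 7710 nM; on these numbers compound 3 sits second highest, with compound 1 the same within the scatter and compound 2 far lower, as the step of a 12-fold higher number from compound 2 to compound 3 (1.09 log units; beyond the scatter) shows. The step of a 1.0-fold lower number from compound 1 to compound 3 (0.00 log units; within the scatter) means that adding two methyl groups around the hydroxyl changed nothing beyond the scatter.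

Compound 4 `COc1ccc(/C=N/NC(=O)Nc2ccc(Oc3ccnc(-c4nncn4CCN(C)C)c3)c(F)c2)c(OC)c1OC` has not yet been measured. It differs from compound 3 as follows: 2,3,4-trimethoxyphenyl in place of 4-hydroxy-3,5-dimethylphenyl on a carbon with a double bond to nitrogen. Among the measured compounds shown here, no measured step swaps the hydroxyl for methoxy groups, so the bearing of the earlier steps is indirect. The step from compound 1 to compound 3 shows that extra small groups on that ring left this assay unchanged, while the step from compound 1 to compound 2 shows that a larger ring system did lower the number strongly. Compound 4 is therefore expected to land near compound 3, with a step of a 1.2-fold higher number from compound 3 to compound 4 (0.07 log units; within the scatter) that is not confidently beyond the scatter. The estimate for compound 4 is 9000 nM, with a range from 3000 nM to 30000 nM.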

Compound 4, half-maximal inhibitory concentration: 7650 nM
Compound 4: the middle estimate sits 1.2-fold (0.07 log units) above what was measured; low and high end bracket the measured number.
By their numbers in this assay, from the lowest: compound 2; then compounds 4, 3 and 1 (each within the scatter of the next).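

What is new here is that a ring with no hydroxyl at all holds its place on this carbon with a double bond to nitrogen: in this assay the 2,3,4-trimethoxyphenyl group, with 0 hydrogen-bond donors against 1 in the group it replaces, gives a 1.0-fold lower number from compound 3 to compound 4 (0.00 log units; within the scatter) and stays level with the plain 4-hydroxyphenyl group in a 1.0-fold lower number from compound 1 to compound 4 (0.01 log units; within the scatter) as well. The two-ring group keeps its distance, with a 12-fold higher number from compound 2 to compound 4 (1.09 log units; beyond the scatter) on record, so among these four compounds only compound 2 stands apart from an otherwise flat set of numbers, and three added methoxy groups did not close that gap. No measurement at hand explains either the flat numbers or the gap.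

The compounds shown cannot separate the hydroxyl of the 2-hydroxynaphthalen-1-yl group from its second ring, and a naphthalen-1-yl group with no hydroxyl, or with a methoxy group in its place, would address that. On these data alone, it also remains open whether this position stays as flat with a phenyl ring carrying an amine or a carboxylic acid, since every ring here carries only hydroxyl, methyl or methoxy groups.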